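Replacing the aryl group on the shared core

The source may hold more compounds than are shown below. What is called first, only, known or untested is meant among the compounds shown, and "the series" means these compounds.

Three compounds share one core and differ only in the aryl group attached to a nitrogen on an aromatic ring. In a functional assay on NCI-H520 cells (Homo sapiens) for inhibition, read by MTT assay, with a stated time of 48 h, tested at 10 uM (on this read-out lower numbers stand for less inhibition and higher numbers for more inhibition at the one concentration tested (going by the name of the read-out)), compound 1 `COc1cc(NC(=O)Nc2cc(Nc3ccc(F)c(Cl)c3)ncn2)cc(OC)c1` gives 25.5%, compound 2 `COc1cc(NC(=O)Nc2cc(Nc3ccc(C)c(F)c3)ncn2)cc(OC)c1` gives 30.6%, and compound 3 `COc1cc(NC(=O)Nc2cc(Nc3cc(F)ccc3OC)ncn2)cc(OC)c1` gives 38%, the highest of the three numbers. Only its gap to compound 1 lies beyond the scatter, as a number 12.5 percentage points higher from compound 1 to compound 3 (beyond the scatter) shows; the steps of a number 5.1 percentage points higher from compound 1 to compound 2 (within the scatter) and a number 7.4 percentage points higher from compound 2 to compound 3 (within the scatter) stay within it. Compound 4 `CCc1cccc(Nc2cc(NC(=O)Nc3cc(OC)cc(OC)c3)ncn2)c1` carries 3-ethylphenyl in place of 5-fluoro-2-methoxyphenyl on a nitrogen on an aromatic ring. Every measured step swapped this same aryl group and moved the number at most modestly, so a similar or slightly lower value is expected. The step of a number 6 percentage points lower from compound 3 to compound 4 (within the scatter) is estimated. Compound 4 is expected to give about 32%, between 20% and 45%.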

Compound 4, a percentage reported as inhibition, at one concentration (the size of the read-out at that concentration, not a potency): 23%
Beside the measured number, compound 4's estimate is 9 percentage points above it, within the range that was stated.
By their numbers in this assay, from the lowest: compounds 4, 1, 2 and 3 (each within the scatter of the next, the first and the last beyond it).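

Replacing the 5-fluoro-2-methoxyphenyl group with 3-ethylphenyl, which has only carbon atoms, gives a number 15 percentage points lower from compound 3 to compound 4 (beyond the scatter) in this assay. The same group leaves the other two compounds within the scatter, with a number 7.6 percentage points lower from compound 2 to compound 4 (within the scatter) and a number 2.5 percentage points lower from compound 1 to compound 4 (within the scatter), so at this position only compound 3 separates from compound 4. No available evidence explains this difference.

As far as these compounds go, it remains open whether the methoxy or the fluoro group of compound 3 matters more. An amine or a carboxylic acid on this aryl ring, or a longer chain in place of ethyl, is also untested among the compounds shown.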